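Adding a methyl group to compound 2

This account rests on a few compounds, and the source may have more. Where it says the series, first, only, none or still open, it means among the compounds named here.

For the measured compounds named here, in a functional assay on K562 cells (Homo sapiens) for antiproliferative activity, read by MTT assay, with a stated time of 5 days (a higher number here means a weaker inhibitor, a lower number a stronger inhibitor), compound 2 (`COc1cc(C(=O)C(=Cc2ccccc2)c2ccccc2)cc(OC)c1OC`) gives 6300000 nM, the higher of the two numbers so far. Compound 1 (`COc1ccc(C=C(C(=O)c2cc(OC)c(OC)c(OC)c2)c2ccc(C)cc2)cc1`) gives 760000 nM, a gap beyond the usual scatter. Compound 3 (`COc1cc(C(=O)C(=Cc2ccccc2)c2ccc(C)cc2)cc(OC)c1OC`) departs from compound 2 in one place: methyl in place of hydrogen on an aromatic carbon, which turns a phenyl into 4-methylphenyl. Compound 1, at 760000 nM, also carries 4-methylphenyl, but it differs from compound 2 elsewhere too, so the data do not isolate the methyl. Part of that gap, not all of it, is therefore the working expectation, pointing to a lower number in this assay. The expected change is a 3.2-fold lower number from compound 2 to compound 3 (0.50 log units; beyond the scatter), a modest step that may only just clear the scatter. Compound 3 is estimated at 2000000 nM, with an expected range of 700000 nM to 6000000 nM.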

Compound 3, half-maximal inhibitory concentration: 2970000 nM
Compound 3: middle estimate off by 1.5-fold (0.17 log units), on the low side; low and high end bracket the measured number.
By their numbers in this assay, from the lowest: compound 1; then compound 3; then compound 2.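

In this assay the methyl now stands alone: on the shared core, phenyl to 4-methylphenyl, para to a large group, gives a modest step beyond the scatter (a 2.1-fold lower number from compound 2 to compound 3 (0.33 log units; beyond the scatter)). With 4-methylphenyl held in place, hydrogen in place of methoxy on an aromatic carbon also gives a modest step beyond the scatter (a 3.9-fold higher number from compound 1 to compound 3 (0.59 log units; beyond the scatter)), so the gap between compound 1 and compound 2 no longer rests on the methyl alone. Nothing available gives a reason for either step.

Open, going by these compounds, is whether the methyl step keeps its size when the methoxy of compound 1 is present. Also open, on these data alone, is how an ethyl group, a chlorine atom or an amine in place of the methyl would compare with compound 3 at this position.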